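Diethylphenyl Variant Tested Against an Assay Ceiling

The compounds below may be only part of what the source reports. "The series", "measured", "known", "first", "only" and "open" are said of these compounds alone.

Three compounds share one core and differ only in the aryl group attached to an aromatic nitrogen. Compound 1, `N#CC1=C(N)Oc2c(N)cc3nc4ccccc4nc3c2C12C(=O)N(Cc1cnnn1-c1cccc(Br)c1)c1ccccc12`, carries a 3-bromophenyl there, and in a functional assay on HCT-116 cells (Homo sapiens) for antiproliferative activity, read by MTT assay, with a stated time of 48 h (a lower number here means a stronger inhibitor, a higher number a weaker inhibitor), compound 1 gives 26100 nM. Compound 2, `CCOc1ccccc1-n1nncc1CN1C(=O)C2(C(C#N)=C(N)Oc3c(N)cc4nc5ccccc5nc4c32)c2ccccc21`, carries a 2-ethoxyphenyl; in this assay compound 2 gives only > 50000 nM, which is a limit of the assay rather than a number. Compound 3, `N#CC1=C(N)Oc2c(N)cc3nc4ccccc4nc3c2C12C(=O)N(Cc1cnnn1-c1ccc([N+](=O)[O-])cc1)c1ccccc12`, carries a 4-nitrophenyl, and in this assay compound 3 likewise gives > 50000 nM, again a limit. So compound 3 stands at the ceiling of what was measured, with the limit of > 50000 nM in this assay, at which 2 of the 3 values shown sit. The changes among the three gave an at least 1.9-fold higher number from compound 1 to compound 2 (0.28 log units; that floor lies within the scatter) and an at least 1.9-fold higher number from compound 1 to compound 3 (0.28 log units; that floor lies within the scatter), while the comparison of the two limits gives a step that the two limits leave unreadable from compound 2 to compound 3.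

Compound 4, `CCc1cccc(CC)c1-n1nncc1CN1C(=O)C2(C(C#N)=C(N)Oc3c(N)cc4nc5ccccc5nc4c32)c2ccccc21`, differs from compound 3 by 2,6-diethylphenyl in place of 4-nitrophenyl on an aromatic nitrogen. Among the measured compounds shown here, no measured step at this nitrogen brought the number down; only compound 1 gave a number rather than a limit. With two of three values at the limit, compound 4 is expected to sit near that ceiling as well, with an at least 1.1-fold lower number from compound 3 to compound 4 (0.04 log units; that floor lies within the scatter). Compound 4 is therefore estimated at 45000 nM in this assay, within 18000 nM to 120000 nM.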

Compound 4, half-maximal inhibitory concentration: 37600 nM
Estimate against measurement, compound 4: 1.2-fold (0.08 log units) above, and the stated range covers the measured number.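

In this assay, compound 4 gives 37600 nM, which makes 2,6-diethylphenyl the second group at this nitrogen to return a number rather than a limit, and it does so with only carbon among its 10 heavy atoms and 0 hydrogen-bond acceptors. Set against the two limits, the change gives an at least 1.3-fold lower number from compound 3 to compound 4 (0.12 log units; that floor lies within the scatter) and an at least 1.3-fold lower number from compound 2 to compound 4 (0.12 log units; that floor lies within the scatter), and neither floor reaches beyond the scatter, so these steps establish no real gain. Set against the only other number at this position, it gives a 1.4-fold higher number from compound 1 to compound 4 (0.16 log units; within the scatter), so 2,6-diethylphenyl and 3-bromophenyl cannot be told apart in this assay.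

Compound 2 and compound 3 remain limits rather than numbers, so their true distance from compound 4 stays unknown: the limit of > 50000 nM in this assay, at which 2 of the 4 values shown sit.

Also open, going by these compounds, is whether an aminomethyl group or a carboxylic acid on the phenyl ring, or a longer chain in place of the two ethyl groups, would bring the number down by more than the scatter.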